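The source may hold more compounds than are shown below. What is called first, only, known or untested is meant among the compounds shown, and "the series" means these compounds.

Compound 2 `COc1cc(-c2nnc3n2NC(c2ccco2)C(C(=O)c2ccco2)S3)cc(OC)c1OC` carries a furan-2-yl on the carbonyl carbon. In a functional assay on HepG2 cells (Homo sapiens) for cytotoxicity, read by MTT assay, with a stated time of 48 h (on this read-out lower numbers stand for stronger inhibition and higher numbers for weaker inhibition), compound 2 gives > 100000 nM, which is a limit of the assay and not a number. Compound 1 `COc1cc(-c2nnc3n2NC(c2cccs2)C(C(=O)c2ccccc2)S3)cc(OC)c1OC` in this assay likewise gives > 100000 nM, again a limit rather than a measured number. The two limits together make up (the limit of > 100000 nM in this assay, at which 2 of the 3 values shown sit). Going by the values given here, compound 3 `COc1cc(-c2nnc3n2NC(c2cccs2)C(C(=O)c2ccc(Cl)cc2)S3)cc(OC)c1OC` is the only compound with a number, giving 13200 nM in this assay. Among the compounds with values here, the single measured step, an at least 7.5-fold lower number from compound 1 to compound 3 (0.87 log units; beyond the scatter), is the only guide available. Compound 4 `COc1cc(-c2nnc3n2NC(c2ccco2)C(C(=O)c2ccc(C(F)(F)F)cc2)S3)cc(OC)c1OC` differs from compound 2 by 4-(trifluoromethyl)phenyl in place of furan-2-yl on a carbonyl carbon. This change is not the same as the measured one, which put chloro in place of hydrogen on an aromatic carbon; here the ring on the carbonyl carbon itself is exchanged. Within the data shown here, still, the compound bearing the chloro, compound 3, is the only one with a number, so a move off the limit is expected. The step of an at least 5.0-fold lower number from compound 2 to compound 4 (0.69 log units; beyond the scatter) is accordingly estimated. Compound 4 is expected to give 20000 nM, between 5000 nM and 100000 nM.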

Compound 4, half-maximal inhibitory concentration: > 100000 nM
Compound 4 was reported as a limit; the forecaster's own chance of this, stated with the estimate: 35%; at least 5.0-fold (0.69 log units) between middle value and limit.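

In this assay compound 2 and compound 4 both stand at a limit and not at a number, so 4-(trifluoromethyl)phenyl in place of furan-2-yl cannot be read as a step: the limit of > 100000 nM in this assay, at which 3 of the 4 values shown sit. The compounds shown leave open whether this exchange on the carbonyl carbon changes the read-out at all.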